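The source may hold more compounds than are shown below. What is called first, only, known or untested is meant among the compounds shown, and "the series" means these compounds.

Going by the values given here, compound 3 `Cc1ccc(-c2ccccc2NCC2=NCCN2)o1` gives 2.69 nM in a functional assay for activation of Alpha-1A adrenergic receptor (Homo sapiens), read by calcium flux (on this read-out higher numbers stand for an effect only at larger amounts of compound and lower numbers for an effect already at smaller amounts), which places it second highest of the three numbers measured so far. Its nearest neighbour is compound 2 `Cc1ccsc1-c1ccccc1NCC1=NCCN1`, which gives 0.851 nM; the furthest is compound 1 `Cc1cc(-c2ccccc2NCC2=NCCN2)on1`, which gives 38.9 nM. Among the measured steps, a 14-fold lower number from compound 1 to compound 3 (1.16 log units; beyond the scatter) and a 3.2-fold higher number from compound 2 to compound 3 (0.50 log units; beyond the scatter), while a 46-fold lower number from compound 1 to compound 2 (1.66 log units; beyond the scatter).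

Compound 4 `CO/N=C(\C)c1ccccc1NCC1=NCCN1` has not yet been measured in this assay. It differs from compound 3 by a group of 5 heavy atoms (3 carbon, 1 nitrogen, 1 oxygen; no ring) in place of a group of 6 heavy atoms (5 carbon, 1 oxygen; one five-membered aromatic ring with 1 hetero atom), on an aromatic carbon. Every measured step at this position exchanges one five-membered aromatic ring for another, and each of those exchanges moved the read-out beyond the scatter, two of them by a large amount. Among the compounds with values here, no measured pair shows what happens when the ring is replaced by a group with no ring, so the direction of the step cannot be read from the data; the only guide is that changes at this position have not been neutral. On that basis a step of moderate size towards a higher number is expected, a 4.5-fold higher number from compound 3 to compound 4 (0.65 log units; beyond the scatter), with a wide range in either direction. Compound 4 is accordingly estimated at 12 nM in this assay, between 2 nM and 80 nM.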

Compound 4, half-maximal effective concentration: 20.9 nM
The estimate for compound 4 lay 1.7-fold (0.24 log units) below the measured number; low and high end bracket the measured number.
By their numbers in this assay, from the lowest: compound 2; then compound 3; then compounds 4 and 1 (each within the scatter of the next).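

In this assay, going by these compounds alone, the first group with no ring at this position gives up part of what the two lowest-reading rings deliver, with a 7.8-fold higher number from compound 3 to compound 4 (0.89 log units; beyond the scatter) and a 25-fold higher number from compound 2 to compound 4 (1.39 log units; beyond the scatter), so the 5-methylfuran-2-yl and 3-methylthiophen-2-yl groups each read clearly lower than the group that replaces them. The picture differs against the 3-methyl-1,2-oxazol-5-yl group, where a 1.9-fold lower number from compound 1 to compound 4 (0.27 log units; within the scatter) leaves the two compounds indistinguishable, which shows that a five-membered aromatic ring at this position does not by itself give a low number: compounds 2 and 3 fit that link between ring and low number, while compound 1 goes against it. No supporting measurement accompanies these numbers to explain the differences.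

Within the data shown here, with only one group lacking a ring in view, it remains open which part of it sets its number, the double bond or the oxygen-bearing end. From the compounds shown here alone, it is also open whether other groups with no ring, such as a plain ethyl chain, a nitrile or an amide, would read near compound 4 or nearer compounds 2 and 3.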